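Adding a Methyl to the Benzyl Group of Compound 1

A few compounds are considered here, and "the series" means these few. Any claim that something is new, unique, unknown or untested is made for them only; others in the source may bear on it.

Measured so far:
Compound 1 `Nc1nc(NCc2ccccc2)nc(-c2ccccc2CO)n1` gives 4.35 in a functional assay on cells for positive allosteric modulation of G-protein coupled receptor 68 (Homo sapiens), read by a luciferase reporter and cAMP accumulation, with a stated time of 30 min, at pH 6.8 and pH 8.3, in the presence of a further agent that is not named here; a higher number here means a more potent compound, by a factor of ten per unit of this negative logarithm, a lower number a less potent compound.
Compound 2 `CNc1nc(NCc2ccccc2)nc(-c2ccccc2CO)n1` gives 4.51 in this assay.
Compound 3 `Nc1nc(NCc2ccccc2)nc(-c2ccc(Cl)cc2CO)n1` gives 4.76 in this assay.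

Among these three, compound 1 has the lowest number. The step of a number 0.16 log units higher from compound 1 to compound 2 (within the scatter) stays within the scatter, while a number 0.41 log units higher from compound 1 to compound 3 (beyond the scatter) is a modest step beyond it. Compound 4 `Cc1ccccc1CNc1nc(N)nc(-c2ccccc2CO)n1` has not yet been measured. It differs from compound 1 by methyl in place of hydrogen on an aromatic carbon. Among the measured compounds shown here, no measured step makes this same change, so the expectation rests on the nearest ones, and both are small: a number 0.16 log units higher from compound 1 to compound 2 (within the scatter) also adds a methyl, on a nitrogen on an aromatic ring, without leaving the scatter, and a number 0.41 log units higher from compound 1 to compound 3 (beyond the scatter) adds a chloro on an aromatic carbon and remains only modest. A methyl on the benzyl group is therefore expected to shift the number little, most likely not beyond the scatter. The estimate for compound 4 in this assay is 4.45, with a range from 4 to 4.9. This corresponds to an expected step of a number 0.10 log units higher from compound 1 to compound 4 (within the scatter).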

Compound 4, negative logarithm of the antagonist equilibrium constant: 4.7
Estimate against measurement, compound 4: 0.25 log units below, and the stated range covers the measured number.
By their numbers in this assay, from the lowest: compounds 1, 2, 4 and 3 (each within the scatter of the next, the first and the last beyond it).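

In this assay, replacing benzyl with 2-methylbenzyl gives a number 0.35 log units higher from compound 1 to compound 4 (beyond the scatter) and so shows that one added methyl on this ring can move the number past the scatter. This position, on an aromatic carbon ortho to a large group, is therefore a second place on the molecule where a small substituent has a modest effect, alongside the chloro change with a number 0.41 log units higher from compound 1 to compound 3 (beyond the scatter) on a different part of the molecule. No measurement here bears on why the methyl raises the number.

Still open, going by these compounds, is whether a chloro, a methoxy or an ethyl at this same position would match, exceed or lose the gain seen with methyl. On these data alone, it is also open whether the 2-methylbenzyl group and the chloro of compound 3 would add up when joined in one compound.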